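A few compounds are considered here, and "the series" means these few. Any claim that something is new, unique, unknown or untested is made for them only; others in the source may bear on it.

Measured in an ADME assay on L6 cells (Rattus norvegicus) for cytotoxicity, read by resazurin assay, with a stated time of 72 h; a lower number here means a stronger inhibitor, a higher number a weaker inhibitor:
compound 1 `CC(=O)OC[C@H]1O[C@@H](N2C(=O)/C(=C3/C(=O)Nc4ccc(Br)cc43)c3ccccc32)[C@H](OC(C)=O)[C@@H](OC(C)=O)[C@@H]1OC(C)=O` gives 7700 nM
compound 2 `CCCC(=O)c1ccc2c(c1)/C(=C1\C(=O)N([C@@H]3O[C@H](COC(C)=O)[C@@H](OC(C)=O)[C@H](OC(C)=O)[C@H]3OC(C)=O)c3ccccc31)C(=O)N2` gives 31700 nM

Of these two, compound 2 holds the higher number. For the measured compounds named here, compound 2, at 31700 nM, is the weaker inhibitor of the pair, and the only measured step (a 4.1-fold higher number from compound 1 to compound 2 (0.61 log units; beyond the scatter)) is modest but beyond the scatter.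

Compound 3 `CNS(=O)(=O)c1ccc2c(c1)/C(=C1\C(=O)N([C@@H]3O[C@H](COC(C)=O)[C@@H](OC(C)=O)[C@H](OC(C)=O)[C@H]3OC(C)=O)c3ccccc31)C(=O)N2` keeps all of compound 2 except one group, with methylsulfamoyl in place of propylcarbonyl on an aromatic carbon. The step from bromo to propylcarbonyl is the only one that bears on this change, as it too swaps a group on an aromatic carbon. Going by the values given here, no measured compound carries methylsulfamoyl, so the direction in this assay remains open. With that single step (a 4.1-fold higher number from compound 1 to compound 2 (0.61 log units; beyond the scatter)) as the guide, a change no larger than it is expected, and most likely none beyond the scatter. The estimate amounts to an expected small drop (a 1.4-fold lower number from compound 2 to compound 3 (0.16 log units; within the scatter)) in the number. For compound 3 the expected value is 22000 nM with 8000 nM to 60000 nM as the estimated range.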

Compound 3, half-maximal inhibitory concentration: 81100 nM
For compound 3 the middle estimate is 3.7-fold (0.57 log units) below the measured one; measured number outside the range, above it.
By their numbers in this assay, from the lowest: compound 1; then compound 2; then compound 3.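

In this assay, this aromatic carbon now has three groups read, and they separate clearly: compound 3 is the weakest inhibitor of the set, with bromo, propylcarbonyl and methylsulfamoyl in rising order of the number. Replacing propylcarbonyl with methylsulfamoyl gives a 2.6-fold higher number from compound 2 to compound 3 (0.41 log units; beyond the scatter), and replacing bromo with methylsulfamoyl gives an 11-fold higher number from compound 1 to compound 3 (1.02 log units; beyond the scatter), the largest step among the three compounds. The two groups in the newest swap have the same heavy-atom count, yet the number still shifts beyond the scatter, and the entering group differs in carrying a hydrogen-bond donor and sulfur, though no measurement here gives a reason for the shift.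

Going by these compounds, what remains open is which part of methylsulfamoyl goes with the higher number, a question that an unsubstituted sulfamoyl group or a dimethylsulfamoyl group on the same aromatic carbon would address. Also open, on these data alone, is where an amine, a carboxylic acid or a longer chain at this carbon would fall in the order of the three groups, and whether that order would hold on a different core.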